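A few compounds are considered here, and "the series" means these few. Any claim that something is new, unique, unknown or untested is made for them only; others in the source may bear on it.

Working notes on the series

Two compounds carry numbers in an assay on CHO cells for displacement of a labelled ligand from adenosine receptor A1 (Homo sapiens), read by scintillation counting, with a stated time of 60 min (a lower number here means a stronger inhibitor, a higher number a weaker inhibitor), so far. Compound 1, `COC(=O)/C(C#N)=C/c1cccc(OC)c1O`, gives 2510 nM in this assay. Compound 2, `COCCNC(=O)c1cc2cccc(OC)c2oc1=N`, gives 6310 nM in this assay, the higher of the two numbers; compound 1 sits at the lower one, and the gap between the two values is beyond the usual scatter. The two share no single-point relation, so nothing more is read from that pair than what the two values show.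

The next compound to be measured is compound 3, `COc1cccc2cc(C(=O)NC3CCCC3)c(=N)oc12`. Against compound 2 it differs in one place: cyclopentyl in place of 2-methoxyethyl on an amide-type nitrogen. The rest of the core is kept.

Among the measured compounds shown here, no measured step exists in this assay that maps onto this change, so the expectation rests on compound 2 alone. The step of a 2.5-fold lower number from compound 2 to compound 3 (0.40 log units; beyond the scatter) is estimated as a modest move toward a lower number, possibly no larger than the scatter. Compound 3 is expected to give about 2500 nM in this assay, with a plausible range from 800 nM to 8000 nM.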

Compound 3, inhibition constant: 3160 nM
Compound 3: the middle estimate sits 1.3-fold (0.10 log units) below what was measured, within the range that was stated.
By their numbers in this assay, from the lowest: compounds 1, 3 and 2 (each within the scatter of the next, the first and the last beyond it).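

In this assay, among the compounds shown here, the swap of cyclopentyl for 2-methoxyethyl on an amide-type nitrogen amounts to a 2.0-fold lower number from compound 2 to compound 3 (0.30 log units; within the scatter) and is the first single-point step, so this position can now be read directly rather than through two unrelated values. The step takes away an open chain carrying one hydrogen-bond acceptor and brings in a five-membered non-aromatic ring of carbon only, yet compound 2 and compound 3 remain indistinguishable within the usual scatter, so at this position the chain's oxygen and the ring show no separable effect on the number. No measurement among the data shown bears on why the two values stay so close.

Going by these compounds, whether this flat reading holds at the position for other groups stays open: a basic chain such as 2-aminoethyl, a carboxylic acid, a phenyl ring or a longer alkyl chain on the same nitrogen could each test it. For the compounds shown here, compound 1 differs from compound 2 and compound 3 in more than one place, so no step to it can be read, and what in the shared core of compound 2 and compound 3 sets the level of their numbers also remains unresolved.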